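Chain amide versus cyclic urea: stability notes

A few compounds are considered here, and "the series" means these few. Any claim that something is new, unique, unknown or untested is made for them only; others in the source may bear on it.

Measured so far:
compound 1 `CC(C)NC(=O)CC(c1ccc(-c2ccc3cccc(F)c3c2)[nH]c1=O)C(C)C` gives < 0.0667 h in an ADME assay on microsomes from liver (Mus musculus) for metabolic stability (a lower number here means that the compound disappears faster, a higher number that the compound lasts longer), a limit of the assay rather than a number.
compound 2 `CC(C)C(Cc1ncc[nH]1)c1ccc(-c2ccc3cccc(F)c3c2)[nH]c1=O` gives < 0.0667 h in this assay, again a limit of the assay.
compound 3 `CC(C)C(c1ccc(-c2ccc3cccc(F)c3c2)[nH]c1=O)N1CCNC1=O` gives 0.682 h in this assay.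

Among the compounds with values here, compound 3 holds the only number recorded; the other two entries sit at the limit of < 0.0667 h in this assay, at which 2 of the 3 values shown sit. Compound 4 `CC(C)C(CC(N)=O)c1ccc(-c2ccc3cccc(F)c3c2)[nH]c1=O` is not yet measured. The change from compound 3 is carbamoylmethyl in place of 2-oxoimidazolidin-1-yl on a saturated chain carbon bound to an aromatic carbon and a saturated chain carbon.

Within the data shown here, two measured steps bear on this. The step of an at least 10-fold higher number from compound 1 to compound 3 (1.00 log units; beyond the scatter) and the step of an at least 10-fold higher number from compound 2 to compound 3 (1.00 log units; beyond the scatter) both run from an open-chain group toward 2-oxoimidazolidin-1-yl, and both are at least modest. Compound 4 goes the other way, back to an open chain carrying a primary amide, closer to compound 1 than to compound 3. The expectation is therefore a step of a 14-fold lower number from compound 3 to compound 4 (1.13 log units; beyond the scatter), downward, and beyond the scatter. Compound 4 is expected to give about 0.05 h, within 0.02 h to 0.15 h, with a fair chance that only a limit is reported.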

Compound 4, half-life: < 0.0667 h
Compound 4: only a limit was reported (the forecaster's own chance of this, stated with the estimate: 60%); the middle value is on the limit's open side.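

In this assay, putting carbamoylmethyl in place of 2-oxoimidazolidin-1-yl on this saturated chain carbon gives an at least 10-fold lower number from compound 3 to compound 4 (1.00 log units; beyond the scatter), so this smaller open-chain primary amide does not keep the half-life of the cyclic urea. Compound 4 gives < 0.0667 h, which is a limit of the assay. The steps among compound 1, compound 2 and compound 4 cannot be read, and among the compounds shown only compound 3, with its cyclic urea, stands off the shared limit: the limit of < 0.0667 h in this assay, at which 3 of the 4 values shown sit.

Compound 3 differs from the open-chain compounds both in having a ring and in being joined to the chain carbon through nitrogen, so the compounds shown do not separate these two features. As far as these compounds go, an open-chain urea or a 2-oxopyrrolidin-1-yl ring on the same carbon would bear on this, and the actual half-lives of compound 1, compound 2 and compound 4 also remain open.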